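A few compounds are considered here, and "the series" means these few. Any claim that something is new, unique, unknown or untested is made for them only; others in the source may bear on it.

Measured so far in a functional assay on HepG2 cells (Homo sapiens) for cytotoxicity, read by MTT assay, with a stated time of 24 h; on this read-out lower numbers stand for stronger inhibition and higher numbers for weaker inhibition:
Compound 1 `COc1ccc(/C=C2\CN(C)C/C(=C\c3ccccc3F)C2=O)cc1` gives 12300 nM
Compound 2 `CN1C/C(=C\c2ccc(C#N)cc2)C(=O)/C(=C/c2ccccc2F)C1` gives 590 nM
Compound 3 `COc1cc(/C=C2\CN(C)C/C(=C\c3ccc(F)cc3)C2=O)cc(OC)c1` gives 6140 nM

In this assay compound 3 gives 6140 nM, within the scatter of compound 1 at 12300 nM, while compound 2 at 590 nM shows a clearly lower number, beyond the scatter. Compound 4 `COc1cc(/C=C2\CN(C)C/C(=C\c3ccc(Cl)c(Cl)c3)C2=O)cc(OC)c1` has not yet been measured. It carries 3,4-dichlorophenyl in place of 4-fluorophenyl on a double-bonded chain carbon bound to a double-bonded ring carbon. Going by the values given here, only one measured step is available, a 21-fold lower number from compound 1 to compound 2 (1.32 log units; beyond the scatter), a large one with cyano in place of methoxy on an aromatic carbon. That step involves neither of the groups exchanged here, so it bears on this change only loosely: it shows that one aromatic substituent can move the number far, but it does not size this exchange. A modest expected move toward a lower number, possibly no larger than the scatter, is therefore all that can be offered, namely a 2.0-fold lower number from compound 3 to compound 4 (0.31 log units; beyond the scatter) as estimated. Compound 4 is estimated at 3000 nM, with 800 nM to 9000 nM as the expected range.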

Compound 4, half-maximal inhibitory concentration: 3840 nM
The estimate for compound 4 lay 1.3-fold (0.11 log units) below the measured number; measured number inside the range.
By their numbers in this assay, from the lowest: compound 2; then compounds 4, 3 and 1 (each within the scatter of the next, the first and the last beyond it).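

In this assay, 3,4-dichlorophenyl in place of 4-fluorophenyl on a double-bonded chain carbon bound to a double-bonded ring carbon gives a 1.6-fold lower number from compound 3 to compound 4 (0.20 log units; within the scatter), so this exchange does not separate the two compounds. Going by these compounds alone, this is the first step read at this position, and it stands apart from the only earlier step, a 21-fold lower number from compound 1 to compound 2 (1.32 log units; beyond the scatter), which is large and involves cyano in place of methoxy on an aromatic carbon. Nothing measured here accounts for the size of the new step.

From the compounds shown here alone, whether an amine or a carboxylic acid on this aromatic ring would move the number beyond the scatter remains open. Going by these compounds, it is also open whether the cyano group of compound 2 would give so large a step if placed on compound 3.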